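Swapping Fluoro for Nitro on a Cell Growth Inhibitor

The source may hold more compounds than are shown below. What is called first, only, known or untested is meant among the compounds shown, and "the series" means these compounds.

Of the compounds shown here, three have been tested in a functional assay on Calu-3 cells (Homo sapiens) for cytotoxicity, read by WST assay, with a stated time of 72 h; on this read-out lower numbers stand for stronger inhibition and higher numbers for weaker inhibition. Compound 2 `Fc1ccc(-c2cc(-c3ccc4[nH]ccc4c3)on2)cc1` gives 16800 nM, the lowest of the two plain numbers in this assay. Compound 1 `COc1ccc(-c2cc(-c3c(Cl)c4ccccc4n3C)no2)cc1` gives 60900 nM, a value that lies beyond the usual scatter above that of compound 2. Compound 3 `COc1ccc(-c2cc(-c3cc4ccccc4[nH]3)no2)cc1` gives > 100000 nM, which is a limit of the assay and not a number. One of the three values therefore sits at the limit of > 100000 nM in this assay, at which 1 of the 3 values shown sits.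

Compound 4 `O=[N+]([O-])c1ccc(-c2cc(-c3ccc4[nH]ccc4c3)on2)cc1` has not yet been measured. It differs from compound 2 in one place: nitro in place of fluoro on an aromatic carbon. Among the measured compounds shown here, no measured pair of compounds here shows this particular change, so the data give no direct guide to its effect. The expectation is that the step in this assay stays small, without a clear direction beyond the scatter. The step from compound 2 to compound 4 is estimated at a 1.3-fold lower number from compound 2 to compound 4 (0.11 log units; within the scatter). In this assay compound 4 is estimated to give about 13000 nM, with a range from 4000 nM to 45000 nM.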

Compound 4, half-maximal inhibitory concentration: 25800 nM
For compound 4 the middle estimate is 2.0-fold (0.30 log units) below the measured one; the measured number falls inside the stated range.
By their numbers in this assay, from the lowest: compounds 2 and 4 (each within the scatter of the next); then compound 1. At a limit, above all of these: compound 3.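

Among the compounds shown, this is the first pair that differs in only one place, so it gives the first direct reading of a change at this aromatic carbon, para to a large group. In this assay nitro in place of fluoro gives a 1.5-fold higher number from compound 2 to compound 4 (0.19 log units; within the scatter) even though nitro brings 3 heavy atoms and 2 hydrogen-bond acceptors where fluoro has 1 heavy atom and 0 hydrogen-bond acceptors. Nothing in the data shown accounts for this outcome.

Going by these compounds, whether an amine or a carboxylic acid on this same carbon would move the number beyond the scatter remains open. Also open, on these data alone, is whether nitro in place of fluoro would give a similar result on a different core, since this single pair shares one core and cannot establish a wider trend.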